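The source may hold more compounds than are shown below. What is called first, only, known or untested is meant among the compounds shown, and "the series" means these compounds.

In an assay for inhibition of solute carrier family 22 member 12 (Homo sapiens), read by scintillation counting, with a stated time of 60 min (on this read-out higher numbers stand for weaker inhibition and lower numbers for stronger inhibition), compound 1 `CCc1oc2cc(OC)ccc2c1C(=O)c1ccc(O)cc1` gives 3920 nM, and compound 2 `CCc1oc2cc(O)ccc2c1C(=O)c1ccc(O)cc1` gives 1130 nM. The move between them is a 3.5-fold lower number from compound 1 to compound 2 (0.54 log units; beyond the scatter), and the change responsible is hydrogen in place of methyl on an oxygen on an aromatic ring. Compound 3 `CCc1oc2ccc(OC)cc2c1C(=O)c1cc(Br)c(O)c(Br)c1` is built on a different core; in this assay compound 3 gives 42 nM, the lowest of the three numbers, and the difference between its core and the core of compound 1 is not broken down here. Compound 4 `CCc1oc2ccc(O)cc2c1C(=O)c1cc(Br)c(O)c(Br)c1` has not yet been measured in this assay. It differs from compound 3 by hydrogen in place of methyl on an oxygen on an aromatic ring, which is the same change as that from compound 1 to compound 2, at a place described in the same words. Because the earlier step of a 3.5-fold lower number from compound 1 to compound 2 (0.54 log units; beyond the scatter) was modest and beyond the usual scatter, a step of similar size and direction is expected here, namely a 3.0-fold lower number from compound 3 to compound 4 (0.48 log units; beyond the scatter). On that basis compound 4 is estimated to give 14 nM in this assay, with a likely range from 5 nM to 45 nM, resting on the single earlier occurrence of this change and the value of compound 3.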

Compound 4, half-maximal inhibitory concentration: 189 nM
Compound 4: middle estimate off by 14-fold (1.13 log units), on the low side, outside the stated range (above it).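

In this assay the change from methoxy to hydroxy does not carry over from one core to the other: the new step runs the opposite way, with a 4.5-fold higher number from compound 3 to compound 4 (0.65 log units; beyond the scatter) on the core of compound 3, whereas the earlier step went down. Set side by side, the two occurrences differ in direction and by more than scatter alone would cover: the same change on two cores in this assay, a 3.5-fold lower number (0.54 log units; beyond the scatter) from compound 1 to compound 2 and a 4.5-fold higher number (0.65 log units; beyond the scatter) from compound 3 to compound 4, 16-fold (1.19 log units) apart, beyond the scatter of two such steps. This shows that, in this series, the effect of this change on one core cannot be assumed to hold on another, but with one pair per core it does not show which feature of the cores sets the direction, nor which direction a further core would follow.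

The compounds shown leave open how a third core would respond to the same change. They also leave open whether an ethoxy group or an amine at that place on the core of compound 3 would follow compound 3 or compound 4.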